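The source may report more compounds than this note shows. Statements on the series, on what has been measured and on what is new or still open speak of the compounds shown alone.

Measured so far in a functional assay on HCT-116 cells (Homo sapiens) for cytotoxicity, read by MTT assay, with a stated time of 72 h; on this read-out higher numbers stand for weaker inhibition and lower numbers for stronger inhibition:
- Compound 1, `Cc1cc(S(=O)(=O)/N=C(\N)n2nccc2-c2ccccc2)c(SCc2cccc3ccccc23)cc1Cl`, gives 7000 nM
- Compound 2, `Cc1cc(S(=O)(=O)/N=C(\N)n2nccc2-c2ccccc2)c(SCc2ccccc2C)cc1Cl`, gives 16000 nM

Going by the values given here, of these two numbers compound 2 carries the higher one, and its only neighbour is compound 1. Among the compounds with values here, the single measured step, a 2.3-fold higher number from compound 1 to compound 2 (0.36 log units; beyond the scatter), is modest and lies beyond the scatter. Compound 3, `Cc1ccc(CSc2cc(Cl)c(C)cc2S(=O)(=O)/N=C(\N)n2nccc2-c2ccccc2)cc1`, is the next candidate; it differs from compound 2 by 4-methylphenyl in place of 2-methylphenyl on a saturated chain carbon bound to a sulfur. Within the data shown here, no measured step moves a methyl from one position of the same ring to another: the step from compound 1 to compound 2 exchanges a whole ring group and only loosely bears on this change. With nothing pointing in either direction, the expected step for compound 3 in this assay is a 1.2-fold lower number from compound 2 to compound 3 (0.09 log units; within the scatter), within the scatter. Compound 3 is therefore estimated at 13000 nM, with a range from 5500 nM to 32000 nM.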

Compound 3, half-maximal inhibitory concentration: 14000 nM
For compound 3 the middle estimate is 1.1-fold (0.03 log units) below the measured one; measured number inside the range.
By their numbers in this assay, from the lowest: compounds 1, 3 and 2 (each within the scatter of the next, the first and the last beyond it).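

In this assay, exchanging 2-methylphenyl for 4-methylphenyl on the saturated chain carbon bound to a sulfur gives a 1.1-fold lower number from compound 2 to compound 3 (0.06 log units; within the scatter), so for this pair the place of the methyl on the ring makes no readable difference. Exchanging naphthalen-1-yl for 4-methylphenyl at the same place gives a 2.0-fold higher number from compound 1 to compound 3 (0.30 log units; within the scatter), which means the gap between naphthalen-1-yl and a methylphenyl group, beyond the scatter for compound 2, is not beyond it for compound 3. No information at hand offers a reason for either result.

Still open, on these data alone, is whether a ring carrying a methoxy group or a carboxylic acid instead of the methyl would shift the number at this place. Equally open, as far as these compounds go, is what an amine or a plain hexyl chain in place of the whole ring would do.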